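Amino acid side chains on the aminoquinone series

The source may report more compounds than this note shows. Statements on the series, on what has been measured and on what is new or still open speak of the compounds shown alone.

Measured so far:
compound 1 `CC1=CCC[C@H]2[C@](C)(CC3=CC(=O)C=C(NCCC(=O)O)C3=O)[C@@H](C)CC[C@]12C`: 15500 nM
compound 2 `CC(C)(C)C1=CC(=O)C=C(NCC(=O)O)C1=O`: 85000 nM
compound 3 `C[C@H](NC1=CC(=O)C=C(C(C)(C)C)C1=O)C(=O)O`: 77600 nM

In a functional assay on K562 cells (Homo sapiens) for cytotoxicity, read by MTT assay, with a stated time of 72 h (on this read-out higher numbers stand for weaker inhibition and lower numbers for stronger inhibition), compound 3 gives 77600 nM, the second highest of the three numbers. Compound 2 is nearest, with 85000 nM in this assay. Compound 1, with 15500 nM in this assay, stands furthest and gives a lower number, the two compounds differing in more than one place, so only their two values can be compared.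

Within the data shown here, the one step so far within the shared core of compounds 2 and 3 is a 1.1-fold lower number from compound 2 to compound 3 (0.04 log units; within the scatter). Among the measured compounds shown here, it is the only measured step that bears on the next one.

Compound 4 `CSCC[C@H](NC1=CC(=O)C=C(C(C)(C)C)C1=O)C(=O)O` is not yet measured. It differs from compound 3 in one place: (methylsulfanyl)methyl in place of hydrogen on a saturated chain carbon, two bonds along the chain from an amine nitrogen and a carbonyl carbon. This is the same chain carbon that carried the change from compound 2 to compound 3, extended once more. Since that step was a 1.1-fold lower number from compound 2 to compound 3 (0.04 log units; within the scatter), no step beyond the scatter is expected here either, in either direction; the expected step is a 1.1-fold lower number from compound 3 to compound 4 (0.04 log units; within the scatter). The estimate for compound 4 in this assay is 70000 nM, with a range of 30000 nM to 160000 nM.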

Compound 4, half-maximal inhibitory concentration: 88500 nM
Compound 4: the middle estimate sits 1.3-fold (0.10 log units) below what was measured, and the stated range covers the measured number.
By their numbers in this assay, from the lowest: compound 1; then compounds 3, 2 and 4 (each within the scatter of the next).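

Within this assay, putting (methylsulfanyl)methyl in place of hydrogen on a saturated chain carbon, two bonds along the chain from an amine nitrogen and a carbonyl carbon, gives a 1.1-fold higher number from compound 3 to compound 4 (0.06 log units; within the scatter), and the full change on the carbon bound to that nitrogen and carbonyl carbon gives a 1.0-fold higher number from compound 2 to compound 4 (0.02 log units; within the scatter). The earlier compounds shown here showed only that a methyl on this carbon left the reading within the scatter; compound 4 extends that observation to a 2-(methylsulfanyl)ethyl chain containing sulfur, so compounds 2, 3 and 4 now stand as one level set across hydrogen, methyl and this longer group. No available evidence accounts for this level set.

On these data alone, a carboxylic acid or an amine at the end of the side chain, or a phenyl ring on it, remains open at this carbon, as does a longer unbranched carbon chain. Also open, as far as these compounds go, is whether the same side chains would read as level on the core of compound 1, which carries a different group on the shared quinone-bearing part and a longer amino acid chain.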